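Sulfonyl aryl variation on a shared bicyclic diamine series

The compounds below may be only part of what the source reports. "The series", "measured", "known", "first", "only" and "open" are said of these compounds alone.

Measured so far:
compound 1 `Cc1ccc(S(=O)(=O)n2ccc3ccc(N4CCN5CCCC5C4)cc32)cc1`: 3.3 nM
compound 2 `O=S(=O)(c1cccc2ccccc12)n1ccc2ccc(N3CCN4CCCCC4C3)cc21`: 1.7 nM
compound 3 `O=S(=O)(c1ccc2ccccc2c1)n1ccc2ccc(N3CCN4CCCCC4C3)cc21`: 3 nM

In an assay on HEK293 cells for displacement of a labelled ligand from 5-hydroxytryptamine receptor 6 (Homo sapiens) (a higher number here means a weaker inhibitor, a lower number a stronger inhibitor), compound 3 gives 3 nM and stands second highest of the three numbers; its nearest neighbour is compound 1 with 3.3 nM and its furthest is compound 2 with 1.7 nM, both gaps within the scatter. Within the data shown here, the only step that can be read directly, a 1.8-fold higher number from compound 2 to compound 3 (0.25 log units; within the scatter), swaps one naphthalenyl for the other on the sulfonyl sulfur and does not move the number beyond the scatter.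

Compound 4 `O=S(=O)(c1ccc(F)cc1F)n1ccc2ccc(N3CCN4CCCCC4C3)cc21` differs from compound 3 by 2,4-difluorophenyl in place of naphthalen-2-yl on a sulfonyl sulfur. Among the measured compounds shown here, no measured pair replaces a bicyclic aryl on the sulfonyl sulfur with a single fluorinated ring, so the step from compound 2 to compound 3 bears on it only in showing that the aryl group on the sulfonyl sulfur has so far been exchanged without a change beyond the scatter. A step of similar size is therefore expected, in either direction, as a 1.7-fold higher number from compound 3 to compound 4 (0.22 log units; within the scatter). Compound 4 is expected to give about 5 nM in this assay, within 1.5 nM to 16 nM.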

Compound 4, inhibition constant: 3.6 nM
Estimate against measurement, compound 4: 1.4-fold (0.14 log units) above; low and high end bracket the measured number.
By their numbers in this assay, from the lowest: compounds 2, 3, 1 and 4 (each within the scatter of the next, the first and the last beyond it).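

In this assay, a single fluorinated ring can stand on a sulfonyl sulfur in place of a bicyclic aryl: a 1.2-fold higher number from compound 3 to compound 4 (0.08 log units; within the scatter) stays within the scatter, so exchanging naphthalen-2-yl for 2,4-difluorophenyl leaves the number effectively unchanged. Among these compounds, the same replacement measured against the other naphthalenyl, a 2.1-fold higher number from compound 2 to compound 4 (0.33 log units; beyond the scatter), is the first step beyond the scatter, although only a modest one, and compound 3 remains within the scatter of both compound 2 and compound 4. Nothing measured here bears on the reason for either step.

Steps involving compound 1 cannot be read, as it differs from the others in more than one place. Also open, going by these compounds, is how the number responds when the sulfonyl sulfur carries an aryl ring bearing an amine or a carboxylic acid, or a plain alkyl chain instead of an aryl ring.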